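This account rests on a few compounds, and the source may have more. Where it says the series, first, only, none or still open, it means among the compounds named here.

Measured compounds in a functional assay on A-431 cells (Homo sapiens) for antiproliferative activity, read by MTT assay, with a stated time of 72 h; on this read-out higher numbers stand for weaker inhibition and lower numbers for stronger inhibition:
compound 1 `C#Cc1cccc(Nc2ncnc3ccc(NC(=O)Nc4ccc(CN5CCN(C)CC5)cc4)cc23)c1` gives 2810 nM
compound 2 `COC(=O)c1cccc(Nc2ncnc3ccc(NC(=O)Nc4ccc(CN5CCN(C)CC5)cc4)cc23)c1` gives 5630 nM
compound 3 `O=C(Nc1ccc(CN2CCCC2)cc1)Nc1ccc2ncnc(Nc3cccc(C(F)(F)F)c3)c2c1` gives 1360 nM

Compound 3 stands lowest of the three numbers in this assay, with compound 1 nearest and compound 2 furthest, both gaps beyond the scatter, so compound 3 is the most potent compound measured here. Among the compounds with values here, the one single-point step on record, a 2.0-fold higher number from compound 1 to compound 2 (0.30 log units; within the scatter), concerns a change on the other side of the shared core and lies within the scatter.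

Compound 4 `O=C(Nc1cccc(CN2CCCC2)c1)Nc1ccc2ncnc(Nc3cccc(C(F)(F)F)c3)c2c1` differs from compound 3 only in 3-((pyrrolidin-1-yl)methyl)phenyl in place of 4-((pyrrolidin-1-yl)methyl)phenyl on an amide-type nitrogen. Within the data shown here, no measured step touches this part of the molecule: compounds 1 and 2 carry a different amine on that ring and a different group on the aniline, so their values only bracket the general range of the series and say nothing about moving the pyrrolidinylmethyl group around the ring. With nothing on record for this change, the step of a 1.5-fold higher number from compound 3 to compound 4 (0.17 log units; within the scatter) is expected to be small and of uncertain direction, and the number for compound 4 is estimated to lie near that of compound 3, at 2000 nM with a range from 700 nM to 6000 nM in this assay.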

Compound 4, half-maximal inhibitory concentration: 1230 nM
Compound 4: middle estimate off by 1.6-fold (0.21 log units), on the high side, and the stated range covers the measured number.
By their numbers in this assay, from the lowest: compounds 4 and 3 (each within the scatter of the next); then compounds 1 and 2 (each within the scatter of the next).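

Within the data shown here, the step of a 1.1-fold lower number from compound 3 to compound 4 (0.04 log units; within the scatter) in this assay is the first reading on where the pyrrolidinylmethyl group sits on this ring, and the two numbers cannot be told apart. Compounds 1 to 3 each carry a single arrangement of their amine-bearing phenyl group, whereas this pair shows that, with the rest of compound 3 unchanged, 3-((pyrrolidin-1-yl)methyl)phenyl and 4-((pyrrolidin-1-yl)methyl)phenyl on the amide-type nitrogen read alike in this cell assay. No supporting measurement bears on this equivalence, so the result remains a bare observation for this one pair.

As far as these compounds go, whether the same equivalence holds with the ethynyl or methoxycarbonyl group of compounds 1 and 2 in place of trifluoromethyl, or with the amine of compound 1 in place of pyrrolidine, remains open. Also open, from the compounds shown here alone, is how this position responds to a different substituent, such as a morpholine or a carboxylic acid in place of the pyrrolidine, or a longer chain in place of the methyl link to the ring.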